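Removing a methyl from an aryl ether in a pyrazole urea

The source may report more compounds than this note shows. Statements on the series, on what has been measured and on what is new or still open speak of the compounds shown alone.

Measured so far:
compound 1, `O=C(Nc1cccc(-n2cc(-c3ccncc3)c(-c3ccc(Cl)c(O)c3)n2)c1)Nc1ccc(Cl)c(Cl)c1`, > 32500 nM
compound 2, `COc1cc(-c2nn(-c3cccc(NC(=O)Nc4ccc(Cl)c(C(F)(F)F)c4)c3)cc2-c2ccncc2)ccc1Cl`, > 32500 nM

Both measured compounds share the same core and a urea linking a phenyl to a second aryl ring. They were tested in a functional assay on CCRF-CEM cells (Homo sapiens) for inhibition, read by sulforhodamine B assay, with a stated time of 48 h; on this read-out lower numbers stand for stronger inhibition of growth and higher numbers for weaker inhibition of growth. Compound 1 gives > 32500 nM, which is a limit of the assay and not a number. Compound 2 gives > 32500 nM, again a limit and not a number. Compound 2 therefore stands at the edge of what this assay can resolve, and so does compound 1 (the limit of > 32500 nM in this assay, at which 2 of the 2 values shown sit). For the measured compounds named here, no step between two measured compounds can be drawn from these two entries.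

Compound 3, `O=C(Nc1cccc(-n2cc(-c3ccncc3)c(-c3ccc(Cl)c(O)c3)n2)c1)Nc1ccc(Cl)c(C(F)(F)F)c1`, has not yet been measured. It differs from compound 2 by hydrogen in place of methyl on an oxygen on an aromatic ring. Compound 1 already carries the hydroxy form on its aryl ring and sits at the limit, so no change beyond the scatter is expected from this step. The expected step from compound 2 to compound 3 is a step that the limit leaves unreadable from compound 2 to compound 3. For compound 3 the estimate in this assay is 40000 nM, with a range from 15000 nM to 100000 nM, and most likely the assay will again report only a limit.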

Compound 3, concentration for total growth inhibition: 2700 nM
Compound 3: middle estimate off by 15-fold (1.17 log units), on the high side; measured number outside the range, below it.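

In this assay, for the compounds shown here, replacing methoxy with hydroxy on the aromatic ring gives an at least 12-fold lower number from compound 2 to compound 3 (1.08 log units; beyond the scatter), the first single change that brings a compound within reach of a measured number. The hydroxy is not enough on its own: trifluoromethyl in place of chloro on an aromatic carbon gives an at least 12-fold lower number from compound 1 to compound 3 (1.08 log units; beyond the scatter), so among these three compounds only compound 3, which carries both hydroxy and trifluoromethyl, gives a number. Both steps start from a limit, so they show the direction and a minimum size but not the full size: the limit of > 32500 nM in this assay, at which 2 of the 3 values shown sit.

What the free hydroxy contributes remains open, since methoxy is the only other form shown at this position, and an amine or an ethoxy group there could point either way. Going by these compounds alone, the trifluoromethyl position is just as thinly covered, with chloro as its only comparison, so a nitrile on that aromatic carbon would be needed to show whether the effect is specific to trifluoromethyl.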